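Methoxy in Place of Fluoro: Expected Cell Growth Read-out

The source may report more compounds than this note shows. Statements on the series, on what has been measured and on what is new or still open speak of the compounds shown alone.

Measured compounds:
compound 1, `COc1ccc(-c2cc(C(C)=O)c3[nH]c(-c4ccccc4)cc3c2)cc1`: 99.2%
compound 2, `CC(=O)c1cc(-c2ccc(F)cc2)cc2cc(-c3ccc(F)cc3)[nH]c12`: 99.8%

Both compounds were tested in a functional assay on MCF7 cells (Homo sapiens) for cytotoxicity, read by MTT assay, with a stated time of 2 days, tested at 0.1 uM; a lower number here means a stronger effect, a higher number a weaker effect of the compound at the concentration tested. In this assay compound 1 gives 99.2%, and compound 2 gives 99.8%. Compound 2 stands at one end of the two numbers, yet compound 1 sits so close to it that the gap lies within the usual scatter of this measurement; the two cannot be told apart, and both leave the cells essentially unharmed at the concentration used.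

Compound 3, `COc1ccc(-c2cc(C(C)=O)c3[nH]c(-c4ccc(F)cc4)cc3c2)cc1`, has not yet been measured. It is drawn from compound 2 by a single change: methoxy in place of fluoro on an aromatic carbon. Compound 1 already carries a methoxyphenyl group at the same place in the shared core, and its number in this assay does not differ from that of compound 2 beyond the scatter. On that basis no step beyond the scatter is expected in either direction. The estimated step from compound 2 to compound 3 is a number 0.8 percentage points lower from compound 2 to compound 3 (within the scatter). Compound 3 is therefore expected to give about 99%, with a range from 90% to 104%.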

Compound 3, a percentage reported as activity, at one concentration (the size of the read-out at that concentration, not a potency): 88.4%
For compound 3 the middle estimate is 10.6 percentage points above the measured one; measured number below the stated range.
By their numbers in this assay, from the lowest: compound 3; then compounds 1 and 2 (each within the scatter of the next).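

In this assay the change from 4-fluorophenyl to 4-methoxyphenyl gives a number 11.4 percentage points lower from compound 2 to compound 3 (beyond the scatter) and so shows that this position can respond to the swap by more than the scatter, which the earlier pair of compounds could not show. Going by these compounds alone, a second single change, fluoro in place of hydrogen on an aromatic carbon, gives a number 10.8 percentage points lower from compound 1 to compound 3 (beyond the scatter) as well, so both steps lead to compound 3, the only one of the three compounds that carries a methoxy and a fluoro together. Both steps are modest, and no measurement shown here says why either of them occurs.

From the compounds shown here alone, with a single compound carrying both groups, it remains open whether the lower number needs this exact pairing or would also appear with another group in place of methoxy, such as an amine, a carboxylic acid or a longer chain like butoxy. The compounds also leave open whether the same steps would hold at other concentrations or in other cells, since all three numbers come from one concentration in one cell line.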